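Fluoro to chloro on the benzyl of compound 1

A few compounds are considered here, and "the series" means these few. Any claim that something is new, unique, unknown or untested is made for them only; others in the source may bear on it.

Working notes on a small lignan-lactone series. Compound 1 `COc1ccc(C[C@H]2COC(=O)[C@@H]2Cc2ccc(OCc3cn(Cc4ccccc4F)nn3)c(OC)c2)cc1OC` and compound 2 `COc1ccc(C[C@H]2COC(=O)[C@@H]2Cc2ccc(OC(=O)CCC(=O)N3CCCCC3)c(OC)c2)cc1OC` share the same core and were tested in an ADME assay on HeLa cells (Homo sapiens) for cytotoxicity, read by MTT assay; a higher number here means a weaker inhibitor, a lower number a stronger inhibitor. Compound 1 gives only a limit in this assay, >= 600000 nM, not a number. Compound 2 gives 128000 nM in this assay. Among the measured compounds shown here, the two compounds differ in more than one place, so no single step between them is counted; the values show only that compound 2 returns a number while compound 1 sits at the limit of >= 600000 nM in this assay, at which 1 of the 2 values shown sits.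

Compound 3 `COc1ccc(C[C@H]2COC(=O)[C@@H]2Cc2ccc(OCc3cn(Cc4ccccc4Cl)nn3)c(OC)c2)cc1OC` is not yet measured. It differs from compound 1 by chloro in place of fluoro on an aromatic carbon.

For the measured compounds named here, no measured pair carries such a change, so the size of the step can only be guessed. A change of this kind, one halogen for another at the same place, is expected to move this assay by little, none beyond the scatter, with compound 3 staying at the same limit as compound 1 in most runs. Compound 3 is therefore estimated at 600000 nM, between 250000 nM and 1500000 nM. The step expected from compound 1 to compound 3 is a number no higher from compound 1 to compound 3 (the limit leaves the size open).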

Compound 3, half-maximal inhibitory concentration: 84500 nM
The estimate for compound 3 lay 7.1-fold (0.85 log units) above the measured number; the whole stated range lies above it.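

Among the compounds shown here, the fluoro-to-chloro change is the first one-place comparison, and in this assay it gives an at least 7.1-fold lower number from compound 1 to compound 3 (0.85 log units; beyond the scatter). For the compounds shown here, a single halogen exchange on an aromatic carbon, ortho to a large group, is therefore enough to bring the 2-chlorobenzyl compound to a measured number, so this position on the benzyl is not silent in this assay, which the earlier compounds could not show. As far as these compounds go, compound 1 gives only a limit and not a number, so the step marks a minimum size and its true size stays unknown: the limit of >= 600000 nM in this assay, at which 1 of the 3 values shown sits.

The compounds shown leave open whether bromo, methyl or trifluoromethyl at this position would move the number as chloro does, or whether an amine or a carboxylic acid there would shift it in either direction. From the compounds shown here alone, they also give no measured property of either halogen, so the step stands as an observation without an explanation, and whether chloro elsewhere on the benzyl would give a similar step remains untested within this set.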